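This account rests on a few compounds, and the source may have more. Where it says the series, first, only, none or still open, it means among the compounds named here.

Three compounds share one core and differ only in the group on the oxygen on the aromatic ring. Compound 1 `O=C1NCc2c1c1c(c3c2c2ccccc2n3CCO)CCc2cc(OC3CCCCC3)ccc2-1` gives 4% in an assay on isolated protein for inhibition of mitogen-activated protein kinase kinase kinase 11 (Homo sapiens), tested at 1 uM; a higher number here means more inhibition at the concentration tested (going by the name of the read-out), a lower number less inhibition. Compound 2 `O=C1NCc2c1c1c(c3c2c2ccccc2n3CCO)CCc2cc(OCCO)ccc2-1` gives 46% in this assay. Compound 3 `O=C1NCc2c1c1c(c3c2c2ccccc2n3CCO)CCc2cc(OCc3ccccn3)ccc2-1` gives 30% in this assay, which places it second highest of the three, below compound 2 and above compound 1. The measured steps are a number 42 percentage points higher from compound 1 to compound 2 (beyond the scatter), a number 26 percentage points higher from compound 1 to compound 3 (beyond the scatter) and a number 16 percentage points lower from compound 2 to compound 3 (beyond the scatter), all beyond the scatter.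

Compound 4 `N#CCCCOc1ccc2c(c1)CCc1c-2c2c(c3c4ccccc4n(CCO)c13)CNC2=O` is the next compound, and it has not yet been measured in this assay. It differs from compound 3 as follows: 2-cyanoethyl in place of pyridin-2-yl on a saturated chain carbon bound to an oxygen on an aromatic ring. Among the measured compounds shown here, the step that bears most directly on this change is the one in which the group on that same saturated chain carbon was exchanged, a number 16 percentage points lower from compound 2 to compound 3 (beyond the scatter), a modest movement; the larger step of a number 42 percentage points higher from compound 1 to compound 2 (beyond the scatter) shows how wide the range across this position can be. For the measured compounds named here, no measured compound carries a 2-cyanoethyl group, so the direction is uncertain, and a step of modest size or none beyond the scatter is expected, no change at the digits printed from compound 3 to compound 4 (within the scatter). In this assay compound 4 is therefore estimated at 30%, within a range from 12% to 50%.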

Compound 4, a percentage reported as inhibition, at one concentration (the size of the read-out at that concentration, not a potency): 46%
Compound 4: middle estimate off by 16 percentage points, on the low side; measured number inside the range.
By their numbers in this assay, from the lowest: compound 1; then compound 3; then compounds 2 and 4 (each within the scatter of the next).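

Exchanging pyridin-2-yl for 2-cyanoethyl on the saturated chain carbon bound to the oxygen gives a number 16 percentage points higher from compound 3 to compound 4 (beyond the scatter) in this assay, so the loss seen with the pyridine-bearing group is not a fixed feature of groups larger than 2-hydroxyethyl. The hydroxy group of compound 2 also proves not to be needed to reach this level, since cyanomethyl in its place gives no change at the digits printed from compound 2 to compound 4 (within the scatter), and two quite different chain ends thus give the same reading within the usual scatter. Against the cyclohexyl group, the 3-cyanopropyl chain gives a number 42 percentage points higher from compound 1 to compound 4 (beyond the scatter), the same size of step as the earlier one to compound 2, and among these four compounds the two groups without a ring, in compound 2 and compound 4, stand above the two with one, in compound 1 and compound 3.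

Nothing in the data given here accounts for these differences. As far as these compounds go, it remains open whether an amine or a carboxylic acid at the end of the chain, or a longer chain ending in a nitrile, would keep this level of inhibition.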